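Methoxypyridinyl in place of pyridinyl on a weak biaryl ether

A few compounds are considered here, and "the series" means these few. Any claim that something is new, unique, unknown or untested is made for them only; others in the source may bear on it.

Compound 1 `Cc1oc(C(=O)O)cc1COc1ccc(-c2ccc(Cl)cc2)cc1` carries a 4-chlorophenyl on the shared core, and in an assay on cells for displacement of a labelled ligand from prostaglandin E2 receptor EP4 subtype (Homo sapiens), read by scintillation counting (a higher number here means a weaker inhibitor, a lower number a stronger inhibitor), compound 1 gives 1000 nM. Compound 2 `Cc1oc(C(=O)O)cc1COc1ccc(-c2ccncc2)cc1` carries pyridin-4-yl in that position instead. In this assay compound 2 reaches only a limit of the assay, > 10000 nM. The step of an at least 10-fold higher number from compound 1 to compound 2 (1.00 log units; beyond the scatter) is thus known only as a bound, and compound 2 stands at the limit of > 10000 nM in this assay, at which 1 of the 2 values shown sits, so its true value may lie anywhere past that point. Compound 3 `COc1ccc(-c2ccc(OCc3cc(C(=O)O)oc3C)cc2)nc1` follows from compound 2 through (5-methoxypyridin-2-yl in place of pyridin-4-yl on an aromatic carbon). Going by the values given here, the only measured step bearing on this change is an at least 10-fold higher number from compound 1 to compound 2 (1.00 log units; beyond the scatter); no measured compound carries a 5-methoxypyridin-2-yl, and a limit gives no anchor for the size of the new step. In this assay compound 3 is therefore expected to give 5000 nM, between 1000 nM and 30000 nM. The expected step of an at least 2.0-fold lower number from compound 2 to compound 3 (0.30 log units; that floor lies within the scatter) is accordingly uncertain in direction as well as in size.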

Compound 3, inhibition constant: 1300 nM
Compound 3: middle estimate off by 3.8-fold (0.59 log units), on the high side; low and high end bracket the measured number.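

In this assay, 5-methoxypyridin-2-yl in place of pyridin-4-yl gives an at least 7.6-fold lower number from compound 2 to compound 3 (0.88 log units; beyond the scatter), so the loss seen with compound 2 does not extend to every six-membered aromatic ring with a hetero atom at this position. Set against the 4-chlorophenyl group, the same ring gives a 1.3-fold higher number from compound 1 to compound 3 (0.11 log units; within the scatter), which leaves compound 1 and compound 3 indistinguishable in this read-out. The step from pyridin-4-yl is known only as a bound, since compound 2 stands at a limit of the assay: the limit of > 10000 nM in this assay, at which 1 of the 3 values shown sits.

The change alters the ring's point of attachment and adds the methoxy group in a single step, so the compounds shown do not separate the contribution of each. They also leave open whether a plain pyridin-2-yl, or an ethoxy group or an amine in place of the methoxy, would hold this level of binding.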